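Swapping bromo for hydroxy in a well-tolerated pair

This account rests on a few compounds, and the source may have more. Where it says the series, first, only, none or still open, it means among the compounds named here.

Compound 1 `O=C(N/N=C/c1cccc(Cl)c1)c1cccnc1`: in an ADME assay on Vero cells (Chlorocebus sabaeus) for cytotoxicity, read by microscopy (a lower number here means that less compound is tolerated, a higher number that more compound is tolerated), compound 1 gives > 100 ug/mL, a limit of the assay.
Compound 2 `O=C(N/N=C/c1cccc(Br)c1)c1cccnc1`: in this assay compound 2 gives >= 100 ug/mL, also a limit.

Compound 2 thus stands at a limit in this assay rather than at a number. For the measured compounds named here, the only measured step, a step that the two limits leave unreadable from compound 1 to compound 2, cannot be sized because of the limit of > 100 ug/mL in this assay, at which 1 of the 2 values shown sits, and (the limit of >= 100 ug/mL in this assay, at which 1 of the 2 values shown sits). Compound 3 `O=C(N/N=C/c1cccc(O)c1)c1cccnc1` differs from compound 2 by hydroxy in place of bromo on an aromatic carbon. Going by the values given here, no measured step bears on this change, so no shift beyond the scatter is expected in this assay. Compound 3 is therefore estimated at 100 ug/mL, with a range from 50 ug/mL to 200 ug/mL. That estimate corresponds to an expected step of a number no higher from compound 2 to compound 3 (the limit leaves the size open).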

Compound 3, minimum cytotoxic concentration: > 100 ug/mL
Compound 3: no number, only a limit; the forecaster's own chance of this, stated with the estimate: 75%; the middle value sits exactly at the limit.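

For the compounds shown here, no step among compound 1, compound 2 and compound 3 can be read in this assay, where all the values are limits: the limit of > 100 ug/mL in this assay, at which 2 of the 3 values shown sit. The same holds for the remaining value: the limit of >= 100 ug/mL in this assay, at which 1 of the 3 values shown sits. The compounds shown leave open where their actual tolerated concentrations lie, and whether chloro, bromo or hydroxy on this aromatic carbon makes any difference.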